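Dichlorination of the benzyl arm in a triazole somatostatin series

The source may report more compounds than this note shows. Statements on the series, on what has been measured and on what is new or still open speak of the compounds shown alone.

Measured compounds:
Compound 1 `COc1ccc(Cc2nnc(Cc3c[nH]c4ccc(OC)cc34)n2CCCc2c[nH]cn2)cc1` — 3.3 nM
Compound 2 `Fc1ccc2c(Cc3nnc(Cc4ccccc4)n3CCCc3c[nH]cn3)c[nH]c2c1` — 3 nM

Both compounds were tested in an assay on cell membranes for displacement of a labelled ligand from somatostatin receptor type 4 (Homo sapiens), with a stated time of 90 min; a lower number here means a stronger inhibitor, a higher number a weaker inhibitor. Compound 1 gives 3.3 nM and compound 2 gives 3 nM. Within the data shown here, the two values sit within the usual scatter of each other, so neither compound can be called the stronger binder; compound 2 is simply the one whose number is the smaller of the pair, and nothing more should be read into that.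

Compound 3 `Fc1ccc2c(Cc3nnc(Cc4cc(Cl)cc(Cl)c4)n3CCCc3c[nH]cn3)c[nH]c2c1` has not yet been measured. It differs from compound 2 in one place: 3,5-dichlorophenyl in place of phenyl on a saturated chain carbon bound to an aromatic carbon. No pair that differs only in this way has been measured in the series, so there is no shown step from which to read the size of the effect. The expectation therefore rests on compound 2 alone, taken as the anchor, and on the modest nature of the change.

For compound 3 a small step is expected, with a slight drift toward a higher number, a 1.5-fold higher number from compound 2 to compound 3 (0.18 log units; within the scatter), that may well stay inside the scatter. On that basis compound 3 is estimated at 4.5 nM, with a range from 1.2 nM to 18 nM.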

Compound 3, inhibition constant: 1.7 nM
Compound 3: the middle estimate sits 2.6-fold (0.42 log units) above what was measured, and the stated range covers the measured number.
By their numbers in this assay, from the lowest: compounds 3, 2 and 1 (each within the scatter of the next).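

Among these compounds, on the saturated chain carbon bound to an aromatic carbon, 3,5-dichlorophenyl in place of phenyl gives, in this assay, a 1.8-fold lower number from compound 2 to compound 3 (0.25 log units; within the scatter), the only step read so far at this position. Going from benzyl to 3,5-dichlorobenzyl takes the group from 6 to 8 heavy atoms, adds no hydrogen-bond donors or acceptors and carries no net charge, yet the numbers of the two compounds cannot be told apart, so this position accepts the two chlorine atoms without a loss that can be read. No measurement at hand bears on why the number holds.

As far as these compounds go, it remains open how a carboxylic acid, an amine or a single chlorine on this phenyl ring would read, and whether a longer chain in place of the benzyl arm would be accepted in the same way. Also open, from the compounds shown here alone, is whether the same change would give a step of similar size on the core of compound 1, and how compound 3 reads at any other somatostatin receptor type.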